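Swapping chloro for tert-butyl on a hydroxamate cap

The compounds below may be only part of what the source reports. "The series", "measured", "known", "first", "only" and "open" are said of these compounds alone.

The measured compounds:
compound 1, `CN1CC(=O)N(Cc2ccc(C(=O)NO)cc2)C1=O`: 119 nM
compound 2, `O=C(NO)c1ccc(CN2C(=O)CN(Cc3ccc(Cl)cc3)C2=O)cc1`: 8.3 nM

Of the compounds shown here, two have been measured so far. In an assay on isolated protein for inhibition of protein deacetylase HDAC6 (Homo sapiens), read by fluorescence, with stated times of 10 min and 2 h (a higher number here means a weaker inhibitor, a lower number a stronger inhibitor), compound 1 gives 119 nM, and compound 2 gives 8.3 nM. Among the compounds with values here, compound 2 thus stands at the lower of the two numbers, and the single measured step, a 14-fold lower number from compound 1 to compound 2 (1.16 log units; beyond the scatter), shows how much the 4-chlorophenyl group on the saturated chain carbon contributes.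

Compound 3, `CC(C)(C)c1ccc(CN2CC(=O)N(Cc3ccc(C(=O)NO)cc3)C2=O)cc1`, has not yet been measured. It differs from compound 2 in one place: tert-butyl in place of chloro on an aromatic carbon. Within the data shown here, no measured step bears directly on this change; the only step known concerns the introduction of the whole 4-chlorophenyl group rather than an exchange of the group on that ring. With the aromatic ring and the rest of the molecule kept, the author expects no step beyond the scatter in this assay, in either direction, and so estimates for compound 3 a step of a 1.2-fold higher number from compound 2 to compound 3 (0.08 log units; within the scatter). Compound 3 is therefore expected to give about 10 nM, within a range of 3 nM to 40 nM.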

Compound 3, half-maximal inhibitory concentration: 40.7 nM
Compound 3: middle estimate off by 4.1-fold (0.61 log units), on the low side; the measured number lies above the stated range.
By their numbers in this assay, from the lowest: compound 2; then compound 3; then compound 1.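

In this assay, the exchange of chloro for tert-butyl on the aromatic carbon para to a large group gives a 4.9-fold higher number from compound 2 to compound 3 (0.69 log units; beyond the scatter), so the group carried at this place on the ring affects the number, and the earlier step, a 14-fold lower number from compound 1 to compound 2 (1.16 log units; beyond the scatter), could not show this because it introduced the whole 4-chlorophenyl group at once. The change is not large enough to remove the advantage of a substituted ring at this end of the molecule: compound 1 gives 119 nM and compound 3 gives 40.7 nM, so compound 3 still has the lower number of the two, and the order of the three compounds is therefore set by both the presence of the ring and the group it carries. Nothing measured alongside these numbers speaks to why tert-butyl gives a higher number than chloro.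

With only these two groups compared at this place, the compounds shown leave open whether the number rises steadily as the group grows from chloro to tert-butyl, or whether the identity of the group matters more than its count of heavy atoms. They also leave open how the ring would read with no group there at all, or with a methyl, a methoxy, an amine or a carboxylic acid on the same aromatic carbon.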